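A few compounds are considered here, and "the series" means these few. Any claim that something is new, unique, unknown or untested is made for them only; others in the source may bear on it.

Measured compounds:
- compound 1, `CCCC[C@H](NC(=O)O[C@@H]1C(=O)N(C(=O)Nc2c(C)noc2C)CC1(C)C)C(=O)C(=O)N[C@H](C)c1ccccc1`: 12 nm/s
- compound 2, `CCCC[C@H](NC(=O)O[C@@H]1C(=O)N(C(=O)c2nc3ccccc3s2)CC1(C)C)C(=O)C(=O)Nc1cc[nH]n1`: 250 nm/s

Both were tested in an ADME assay on MDCK cells (Canis lupus familiaris) for permeability; a lower number here means that the compound crosses the layer more slowly, a higher number that the compound crosses the layer faster. Compound 2, with 250 nm/s, gives the higher of the two numbers; compound 1, with 12 nm/s, sits well below it, and that gap lies beyond the usual scatter of repeated measurements. The next compound, compound 3, `CCCC[C@H](NC(=O)O[C@@H]1C(=O)N(C(=O)c2nnc(C(F)(F)F)s2)CC1(C)C)C(=O)C(=O)Nc1cc[nH]n1`, keeps the whole of compound 2 apart from one exchange: 5-(trifluoromethyl)-1,3,4-thiadiazol-2-yl in place of 1,3-benzothiazol-2-yl on a carbonyl carbon. Within the data shown here, no measured pair here shows what such an exchange does on its own, so the expectation must rest on compound 2 alone. The step from compound 2 to compound 3 in this assay is estimated to be small, slightly downward, and likely within the scatter, as a 1.6-fold lower number from compound 2 to compound 3 (0.19 log units; within the scatter). Compound 3 is therefore expected to give about 160 nm/s in this assay, with a range from 50 nm/s to 400 nm/s.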

Compound 3, apparent permeability: 120 nm/s
Compound 3: the middle estimate sits 1.3-fold (0.12 log units) above what was measured, within the range that was stated.
By their numbers in this assay, from the lowest: compound 1; then compound 3; then compound 2.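

Among these compounds, this is the first pair here that differs in only one place, so it gives the first direct reading of a change on the carbonyl carbon attached to the ring's amide-type nitrogen. In this assay, exchanging 1,3-benzothiazol-2-yl for 5-(trifluoromethyl)-1,3,4-thiadiazol-2-yl gives a 2.1-fold lower number from compound 2 to compound 3 (0.32 log units; beyond the scatter), a modest step, even though the two groups have the same heavy-atom count and neither has a hydrogen-bond donor. Nothing measured here explains this step.

The exchange changes the ring system, its hetero atoms and the trifluoromethyl group together, so the compounds shown do not separate their contributions. A 1,3,4-thiadiazol-2-yl group carrying methyl instead of trifluoromethyl, or a plain phenyl group at this carbonyl, would begin to separate them.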